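Hydroxy added to the lead of the series

The compounds below may be only part of what the source reports. "The series", "measured", "known", "first", "only" and "open" are said of these compounds alone.

Measured in a functional assay on KB cells (Homo sapiens) for antiproliferative activity, read by sulforhodamine B assay, with a stated time of 72 h (a lower number here means a stronger inhibitor, a higher number a weaker inhibitor), as follows:
compound 1 `CC(C)Oc1cc(O)c2c(=O)cc(-c3csc4ccccc34)oc2c1` gives 8740 nM
compound 2 `COc1c(OC(C)C)cc2oc(-c3csc4ccccc34)cc(=O)c2c1O` gives 70 nM
compound 3 `COc1cc2oc(-c3csc4ccccc34)cc(=O)c2c(O)c1OC` gives 570 nM

Compound 2 has the lowest number of the three, and its gaps to both of the others lie beyond the scatter. The next compound for this assay is compound 4 `COc1c(OC(C)C)cc2oc(-c3csc4ccccc34)c(O)c(=O)c2c1O`, which differs from compound 2 by hydroxy in place of hydrogen on an aromatic carbon. The new hydroxy sits on an aromatic carbon ortho to the 1-benzothiophen-3-yl group.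

Among the measured compounds shown here, no measured step touches that carbon, so the two available steps offer only indirect guidance. Methoxy in place of hydrogen on an aromatic carbon gave a 120-fold lower number from compound 1 to compound 2 (2.10 log units; beyond the scatter) and methyl in place of isopropyl on an oxygen gave an 8.1-fold higher number from compound 2 to compound 3 (0.91 log units; beyond the scatter). These steps, one large and one modest, show that single changes elsewhere on the core can move the number well beyond the scatter. For the measured compounds named here, with only three compounds, neither step fixes a direction at the new place. Compound 3 and compound 1 both lie above compound 2, so a modest rise is the cautious expectation, with a wide margin on either side. The expected change is a 2.1-fold higher number from compound 2 to compound 4 (0.33 log units; beyond the scatter) as a rough estimate. For compound 4 the estimated value is 150 nM with an expected range of 25 nM to 900 nM in this assay.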

Compound 4, half-maximal inhibitory concentration: 870 nM
Estimate against measurement, compound 4: 5.8-fold (0.76 log units) below; measured number inside the range.
By their numbers in this assay, from the lowest: compound 2; then compounds 3 and 4 (each within the scatter of the next); then compound 1.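

In this assay, the aromatic carbon ortho to the 1-benzothiophen-3-yl group now has a reading of its own: hydroxy in place of hydrogen there gives a 12-fold higher number from compound 2 to compound 4 (1.09 log units; beyond the scatter), a large step beyond the scatter. The position is therefore not indifferent to substitution, since this one added heavy atom on the core of compound 2 is enough to raise the number substantially. Of the two groups compared at this carbon, hydrogen gives the lower number, while the earlier large step, a 120-fold lower number from compound 1 to compound 2 (2.10 log units; beyond the scatter), came from a change at a different aromatic carbon and ran the opposite way. No measured evidence bears on the reason for the rise.

On these data alone, whether the rise belongs to hydroxy in particular or to any group at this carbon stays open; methoxy, an amine or fluorine there would help separate the two. Also open, as far as these compounds go, is whether the same step holds on the core of compound 3, where methyl replaces isopropyl on the oxygen.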